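From benzyl to 4-hydroxyphenyl: one swap, one open number

The source may hold more compounds than are shown below. What is called first, only, known or untested is meant among the compounds shown, and "the series" means these compounds.

In a physicochemical assay for lipophilicity (on this read-out lower numbers stand for lower lipophilicity and higher numbers for higher lipophilicity), compound 2 (`Nc1ccccc1NC(=O)c1ccc(CNC2=N[C@@H](Cc3ccccc3)CO2)cc1`) reads 4.15 and ranks second highest of three numbers. Compound 3 (`Nc1ccccc1NC(=O)c1ccc(CNC2=NC(c3ccc(C(F)(F)F)cc3)CO2)cc1`) sits higher at 4.72 and compound 1 (`Nc1ccccc1NC(=O)c1ccc(CNC2=N[C@@H](c3ccccc3)CN2)cc1`) sits lower at 3.46 with both gaps beyond the scatter, the spread expected when a measurement is repeated.

Compound 4 (`Nc1ccccc1NC(=O)c1ccc(CNC2=N[C@@H](c3ccc(O)cc3)CO2)cc1`) has yet to be measured. It carries 4-hydroxyphenyl in place of benzyl on a saturated ring carbon. Among the compounds with values here, no two measured compounds differ in a single place, so the data offer no direct example of how far one such change moves the number. Within the data shown here, none of the measured compounds carries a 4-hydroxyphenyl either, which leaves the expectation resting on the swap itself and on the span of the three known values.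

A lower number is expected in this assay and the estimated change is a number 0.75 log units lower from compound 2 to compound 4 (beyond the scatter) which would lie beyond the scatter. For compound 4 the estimated value is 3.4 with an expected range from 2.9 to 3.9 as its limits.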

Compound 4, partition coefficient: 2.13
For compound 4 the middle estimate is 1.27 log units above the measured one; the measured number lies below the stated range.
By their numbers in this assay, from the lowest: compound 4; then compound 1; then compound 2; then compound 3.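

Within the data shown here, this is the first step between two measured compounds that differ in one place. In this assay, 4-hydroxyphenyl in place of benzyl on a saturated ring carbon gives a number 2.02 log units lower from compound 2 to compound 4 (beyond the scatter), a large step. Both groups count 7 heavy atoms and one six-membered aromatic ring of carbon only, yet the entering group holds an oxygen in place of a carbon and adds 1 hydrogen-bond donor and 1 hydrogen-bond acceptor, so a large step can come with no change in heavy-atom count. Nothing measured here explains the size of the step.

The compounds shown leave open how much of the step belongs to the oxygen and how much to the change from benzyl to a phenyl frame. A plain phenyl on this carbon could separate the two, while 4-methoxyphenyl or 4-aminophenyl could show how other groups behave there.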